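Oxetane ether on the distal ring of compound 1

A few compounds are considered here, and "the series" means these few. Any claim that something is new, unique, unknown or untested is made for them only; others in the source may bear on it.

The measured compounds are:
compound 1, `CC#CC(CC(=O)O)c1ccc(OCc2cccc(-c3c(C)cccc3C)c2)s1`: 210 nM
compound 2, `CCO[C@H](CC(=O)O)c1ccc(OCc2cccc(-c3c(C)cccc3C)c2)s1`: 50 nM
compound 3, `CCOC(CC(=O)O)c1ccc(OCc2cccc(-c3c(C)cccc3C)c2)s1`: 57 nM

In a functional assay on cells for agonist activity at Free fatty acid receptor 1 (Homo sapiens), read by calcium flux (a lower number here means that less compound is needed, a higher number that more compound is needed for the effect), compound 1 gives the highest of the three numbers. The step of a 4.2-fold lower number from compound 1 to compound 2 (0.62 log units; beyond the scatter) and the step of a 3.7-fold lower number from compound 1 to compound 3 (0.57 log units; beyond the scatter) both replace the prop-1-yn-1-yl branch on the chain carbon with ethoxy, and both lower the number by a modest amount. Compound 2 and compound 3 differ only in that (the fact that one of compounds 2 and 3 is drawn with a defined configuration and the other without, at the place where they differ); their numbers lie within the scatter of each other.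

Compound 4, `CC#CC(CC(=O)O)c1ccc(OCc2cccc(-c3c(C)cc(OCC4(C)COC4)cc3C)c2)s1`, keeps the chain of compound 1 unchanged and alters the far aromatic ring: (3-methyloxetan-3-yl)methoxy in place of hydrogen on an aromatic carbon. For the measured compounds named here, none of the measured steps touches this ring, so the set gives no direct guide to its effect. Compound 4 is therefore expected to stay close to compound 1, with a step of a 1.1-fold lower number from compound 1 to compound 4 (0.02 log units; within the scatter), and its number in this assay is estimated at 200 nM, in the range 60 nM to 700 nM.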

Compound 4, half-maximal effective concentration: 450 nM
Compound 4: middle estimate off by 2.3-fold (0.35 log units), on the low side; the measured number falls inside the stated range.
By their numbers in this assay, from the lowest: compounds 2 and 3 (each within the scatter of the next); then compound 1; then compound 4.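

For the compounds shown here, compound 4 gives the first reading on the far aromatic ring, at the carbon meta to two methyl groups and para to a large group, which no earlier step had touched. In this assay, (3-methyloxetan-3-yl)methoxy at this carbon produces a 2.1-fold higher number from compound 1 to compound 4 (0.33 log units; beyond the scatter), so this position is not indifferent to substitution, and the number moves in the opposite direction to the chain change in a 3.7-fold lower number from compound 1 to compound 3 (0.57 log units; beyond the scatter). The available evidence concerns only how compounds 2 and 3 are drawn and does not bear on this ring.

The compounds shown leave open whether a methoxy or a hydroxyl at this carbon would move the number as this ether does, and whether the oxetane ring itself matters. They also leave open whether the ether has the same effect on the ethoxy chain of compound 2.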